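Hydroxy on the phenyl ring of compound 2

A few compounds are considered here, and "the series" means these few. Any claim that something is new, unique, unknown or untested is made for them only; others in the source may bear on it.

In a functional assay on HepG2 cells (Homo sapiens) for antiproliferative activity, read by MTT assay, with a stated time of 48 h (a lower number here means a stronger inhibitor of growth, a higher number a weaker inhibitor of growth), compound 1 `COC(=O)N1N=C(c2ccccc2)CC1c1cc(OC)c(OC)c(OC)c1` gives 3950 nM and compound 2 `CCOC(=O)N1N=C(c2ccccc2)CC1c1cc(OC)c(OC)c(OC)c1` gives 5950 nM, with a 1.5-fold higher number from compound 1 to compound 2 (0.18 log units; within the scatter). Compound 3 `COc1cc(C2CC(c3ccccc3)=NN2C(=O)OCc2ccccc2)cc(OC)c1OC` reads > 10000 nM, which is a limit of the assay. Against that limit the record shows an at least 2.5-fold higher number from compound 1 to compound 3 (0.40 log units; beyond the scatter), and also an at least 1.6-fold higher number from compound 2 to compound 3 (0.22 log units; that floor lies within the scatter). Within the data shown here, compound 2 therefore stands level with compound 1 within the scatter, and it has the only other numerical value.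

Compound 4 `CCOC(=O)N1N=C(c2cccc(O)c2)CC1c1cc(OC)c(OC)c(OC)c1` differs from compound 2 by hydroxy in place of hydrogen on an aromatic carbon, that is, phenyl to 3-hydroxyphenyl. All three measured steps replace a group on the saturated chain carbon, and none touches this aromatic ring, so they give no direct size for the change. Taking compound 2 at 5950 nM as the anchor, no step beyond the scatter is expected, and no direction is favoured with any confidence. The estimated result is a 1.3-fold lower number from compound 2 to compound 4 (0.12 log units; within the scatter). For compound 4 the expected value is 4500 nM, with an estimated range of 1500 nM to 10000 nM.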

Compound 4, concentration for 50% growth inhibition: 1790 nM
Compound 4: the middle estimate sits 2.5-fold (0.40 log units) above what was measured, and the stated range covers the measured number.
By their numbers in this assay, from the lowest: compound 4; then compounds 1 and 2 (each within the scatter of the next). At a limit, above all of these: compound 3.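

Among these compounds, the phenyl ring, which none of the earlier steps on the saturated chain carbon touched, responds to substitution: in this assay, phenyl to 3-hydroxyphenyl gives a 3.3-fold lower number from compound 2 to compound 4 (0.52 log units; beyond the scatter). Among the steps shown, this is the only one that lowers the number beyond the scatter; the earlier changes on the chain either stay within the scatter or raise the number. Nothing shown here gives a cause for this step.

A single hydroxy at a single place leaves open whether the step belongs to hydroxy itself or would also follow from another group there, such as methoxy, an amine or a carboxylic acid. Also open, on these data alone, is whether the same change made on compound 1 would give a step of like size.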